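The source may hold more compounds than are shown below. What is called first, only, known or untested is meant among the compounds shown, and "the series" means these compounds.

Compound 2 `CN(C)c1cc2[nH]c(C3CCCCC3)nc2cc1NC(=O)OCc1ccccc1` is the point of departure. In an ADME assay on Vero cells (Chlorocebus sabaeus) for cytotoxicity, read by resazurin assay, with a stated time of 3 days (a lower number here means a stronger inhibitor, a higher number a weaker inhibitor), compound 2 gives > 100 ug/mL, which is a limit of the assay and not a number. Compound 1 `CCN(CC)c1cc2[nH]c(C3CCCCC3)nc2cc1NC(=O)OCCOCCOC` gives in this assay > 100 ug/mL, likewise a limit. Compound 3 `CCCN(CCC)c1cc2[nH]c(C3CCCCC3)nc2cc1NC(=O)OCc1ccccc1` gives in this assay > 100 ug/mL, again a limit. For the measured compounds named here, every value measured so far therefore rests at the limit of > 100 ug/mL in this assay, at which 3 of the 3 values shown sit, so compound 2 stands nowhere in particular among them: all three are indistinguishable at that limit. Going by the values given here, the single measured step, a step that the two limits leave unreadable from compound 2 to compound 3, stays unreadable, as both of its ends are limits, and it concerns a different position in any case.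

Compound 4 `CN(C)c1cc2[nH]c(C3CCCCC3)nc2cc1NC(=O)OCC(F)(F)F` differs from compound 2 by trifluoromethyl in place of phenyl on a saturated chain carbon bound to an oxygen next to a carbonyl group. Among the compounds with values here, no measured step touches this position, so nothing argues for a shift in either direction. Compound 4 is accordingly expected to give about 150 ug/mL in this assay, within a range of 60 ug/mL to 400 ug/mL. The expected step that the limit leaves unreadable from compound 2 to compound 4 is none beyond the scatter, and compound 4 is most likely to be reported only as a limit.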

Compound 4, half-maximal inhibitory concentration: > 100 ug/mL
Compound 4: no number, only a limit; the forecaster's own chance of this, stated with the estimate: 85%; the middle value lies beyond the limit too.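

No new step can be read between compound 2 and compound 4, since both values are limits of the assay: the limit of > 100 ug/mL in this assay, at which 4 of the 4 values shown sit.

The compounds shown leave open how far past that limit each lies, and whether trifluoromethyl in place of phenyl shifts the result in this assay at all.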